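The source may hold more compounds than are shown below. What is called first, only, known or untested is meant among the compounds shown, and "the series" means these compounds.

Measured so far in the series:

Compound 1 `O=C(Nc1ccc(Cl)cc1)C1CCCN(C(=O)c2cccc(-c3ccco3)c2)C1` gives 0% in an ADME assay on PC-3 cells (Homo sapiens) for cytotoxicity, read by WST assay, tested at 100 uM; a higher number here means more inhibition at the concentration tested (going by the name of the read-out), a lower number less inhibition.
Compound 2 `O=C(Nc1cccc([N+](=O)[O-])c1)C1CCCN(C(=O)c2cc(C(F)(F)F)cc(C(F)(F)F)c2)C1` gives 9% in this assay.

Two compounds, two numbers, both at the low end of the read-out. Within the data shown here, compound 2 carries the higher of the two readings, but the gap to compound 1 is within the usual scatter, so the two are not separated by these data; nothing so far shows a compound that clearly inhibits the cells at the tested concentration.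

The next compound, compound 3 `Cn1cnnc1-c1cccc(NC(=O)C2CCCN(C(=O)c3cc(C(F)(F)F)cc(C(F)(F)F)c3)C2)c1`, shares the core of compound 2 and differs from it in one place: 4-methyl-4H-1,2,4-triazol-3-yl in place of nitro on an aromatic carbon. Among the measured compounds shown here, no measured pair isolates a change of this kind, so there is no step to lean on. Since both measured compounds sit near the floor of the read-out, the expectation is a step from compound 2 to compound 3 of a number 1 percentage points lower from compound 2 to compound 3 (within the scatter), that is, none beyond the scatter.

For compound 3 in this assay the estimate is 8%, with a range from 0% to 25%.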

Compound 3, a percentage reported as inhibition, at one concentration (the size of the read-out at that concentration, not a potency): 0%
Beside the measured number, compound 3's estimate is 8 percentage points above it; measured number inside the range.
By their numbers in this assay, from the lowest: compounds 1, 3 and 2 (each within the scatter of the next).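

Among these compounds, the swap of nitro for 4-methyl-4H-1,2,4-triazol-3-yl, on an aromatic carbon meta to a large group, is the first change confined to one place, and in this assay the step reads a number 9 percentage points lower from compound 2 to compound 3 (within the scatter) and does not separate the two compounds. At this position, a group of 3 heavy atoms with no ring and a five-membered aromatic ring of 6 heavy atoms therefore give readings that these data cannot tell apart, and both stay at the low end of the read-out. The compounds shown offer no measurement that could explain this outcome.

Among the compounds shown here, whether any group on this carbon can give a reading clearly beyond the scatter from compound 2 remains open, as the position is covered by only two groups, neither of them an amine, a carboxylic acid or a longer alkyl chain. Also open, going by these compounds, is how a single change elsewhere on the core of compound 2 would read, for instance a carboxylic acid in place of one trifluoromethyl.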